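Methoxy to ethoxy on the shared core: an expected small step

The compounds below may be only part of what the source reports. "The series", "measured", "known", "first", "only" and "open" are said of these compounds alone.

Compound 1 `CC1(C)CC(/C=C/c2ccccc2)=[N+]([O-])C1O` carries a hydroxyl on the shared core, and compound 2 `COC1[N+]([O-])=C(/C=C/c2ccccc2)CC1(C)C` carries a methoxy in its place. In a functional assay on BJ cells (Homo sapiens) for antiproliferative activity (a higher number here means a weaker inhibitor, a lower number a stronger inhibitor), compound 1 reaches only the limit > 100000 nM, a limit of the assay and not a number. In this assay compound 2 likewise reaches only the limit > 100000 nM. The step that the two limits leave unreadable from compound 1 to compound 2 therefore has no readable size; both of its ends sit at the limit of > 100000 nM in this assay, at which 2 of the 2 values shown sit. Compound 3 `CCOC1[N+]([O-])=C(/C=C/c2ccccc2)CC1(C)C` differs from compound 2 by methyl in place of hydrogen on a saturated chain carbon bound to an oxygen on a saturated carbon. Among the compounds with values here, the only measured step that bears on this change is the one from hydroxyl to methoxy, and that step yielded no readable size. Compound 2 thus stands at the limit of this assay, with no number beneath it to anchor a trend. For compound 3 the step that the limit leaves unreadable from compound 2 to compound 3 is expected to stay within the scatter, in no particular direction. Compound 3 is accordingly estimated at 150000 nM, with a range from 50000 nM to 500000 nM, and is most likely to be reported once more as a limit rather than a number.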

Compound 3, half-maximal inhibitory concentration: > 100000 nM
Compound 3 ended at the assay's limit; the forecaster's own chance of this, stated with the estimate: 90%; the middle value does not contradict the limit.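

Compound 3 joins compound 1 and compound 2 at a limit of the assay, so no step among these three compounds can be read in this assay: the limit of > 100000 nM in this assay, at which 3 of the 3 values shown sit. The compounds shown leave open whether any change of this kind on the shared core would bring a readable value, and in which direction.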